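The source may report more compounds than this note shows. Statements on the series, on what has been measured and on what is new or still open speak of the compounds shown alone.

Measured so far in a physicochemical assay for solubility, read by nephelometry, measured as kinetic solubility, at pH 6.5; on this read-out higher numbers stand for higher solubility and lower numbers for lower solubility:
- compound 1 `NCc1csc(NC(=O)c2ccccn2)n1`: > 100 ug/mL, a limit of the assay
- compound 2 `NCc1csc(NC(=O)c2ncccn2)n1`: > 100 ug/mL, a limit of the assay
- compound 3 `CC(C)(C)c1cc(C(=O)Nc2ccccn2)n(Cc2ccccc2)n1`: 6.3 ug/mL

Going by the values given here, compound 3 reads 6.3 ug/mL, the only actual number in this small set. The other two entries give no number, and what they share is the limit of > 100 ug/mL in this assay, at which 2 of the 3 values shown sit. Those two results are limits and cannot serve as a baseline for a step.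

The account now turns to compound 4 `Cc1csc(NC(=O)c2cc(C(C)(C)C)nn2Cc2ccccc2)n1`, which has not yet been measured. It carries 4-methyl-1,3-thiazol-2-yl in place of pyridin-2-yl on an amide-type nitrogen. The rest of compound 3 stays unchanged.

Among the compounds with values here, the measured set holds no pair that differs in one place only. It therefore gives no measured size for a change of this kind, and the expectation has a single anchor, compound 3 at 6.3 ug/mL. The expected step in this assay is a 1.6-fold lower number from compound 3 to compound 4 (0.20 log units; within the scatter), small and downward, and it may well stay within the usual scatter. A reading at the upper limit of this assay is not expected. For compound 4 the estimate is 4 ug/mL, with an expected range of 1.5 ug/mL to 10 ug/mL.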

Compound 4, solubility: < 1.6 ug/mL
Compound 4: no number, only a limit; the forecaster's own chance of this, stated with the estimate: 10%; middle value at least 2.5-fold (0.39 log units) from the limit.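

Going by these compounds alone, the position on the amide-type nitrogen matters: in this assay, placing 4-methyl-1,3-thiazol-2-yl where pyridin-2-yl stood gives an at least 3.9-fold lower number from compound 3 to compound 4 (0.59 log units; beyond the scatter), the first step between two measured compounds that differ in one place. Compound 4 is read only as a limit of the assay, not as a number, and so the step has a lower bound on its size but no end to it: the limit of < 1.6 ug/mL in this assay, at which 1 of the 4 values shown sits. The leaving and the entering group hold the same count of heavy atoms, so that count does not account for a step lying beyond the scatter, while they differ in ring size, in hetero atoms and in the count of hydrogen-bond acceptors.

The change swaps the ring and adds the methyl at once, so the compounds shown cannot tell how much of the step belongs to each, and a plain 1,3-thiazol-2-yl on the same nitrogen would be needed to separate them. Also open, from the compounds shown here alone, is whether an amine or a carboxylic acid on the thiazole ring, with the rest of compound 4 unchanged, would bring the reading back into the measurable range of the assay.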